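2-Bromobenzyl to 2-methoxybenzyl: a series at its limit

A few compounds are considered here, and "the series" means these few. Any claim that something is new, unique, unknown or untested is made for them only; others in the source may bear on it.

Compound 1 `OC[C@H]1O[C@@H](n2cnc3c(NCc4ccccc4F)ncnc32)[C@H](O)[C@@H]1O`: > 166000 nM (limit)
Compound 2 `OC[C@H]1O[C@@H](n2cnc3c(NCc4ccccc4Cl)ncnc32)[C@H](O)[C@@H]1O`: > 166000 nM (limit)
Compound 3 `OC[C@H]1O[C@@H](n2cnc3c(NCc4ccccc4Br)ncnc32)[C@H](O)[C@@H]1O`: > 166000 nM (limit)

In a functional assay on MCF cells (Homo sapiens) for antiproliferative activity, with a stated time of 72 h (a lower number here means a stronger inhibitor, a higher number a weaker inhibitor), compound 3 gives > 166000 nM, which is a limit and not a number. It has no numerical rank in the series, since every measured compound stands at the same place: the limit of > 166000 nM in this assay, at which 3 of the 3 values shown sit.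

Compound 4 `COc1ccccc1CNc1ncnc2c1ncn2[C@@H]1O[C@H](CO)[C@@H](O)[C@H]1O` carries methoxy in place of bromo on an aromatic carbon, ortho to a large group: methoxy in place of bromo on an aromatic carbon. The 2-bromobenzyl group thus becomes 2-methoxybenzyl, with the shared core unchanged.

The measured steps that bear on this change are the exchanges among fluoro, chloro and bromo at that same place: a step that the two limits leave unreadable from compound 1 to compound 2, a step that the two limits leave unreadable from compound 1 to compound 3 and a step that the two limits leave unreadable from compound 2 to compound 3. None of them has a readable size, so they offer no direction and no magnitude to carry over. Within the data shown here, no compound yet gives a number, and methoxy itself has not been measured here.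

The estimated step is a step that the limit leaves unreadable from compound 3 to compound 4, with no direction supported by the data. For compound 4 the expected value is 170000 nM, estimated to lie between 90000 nM and 300000 nM, and a further limit is the most likely report.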

Compound 4, half-maximal inhibitory concentration: > 166000 nM
Compound 4 ended at the assay's limit; the forecaster's own chance of this, stated with the estimate: 85%; the middle value lies beyond the limit too.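

Compound 4 gives > 166000 nM, a limit and not a number. Among these compounds, its steps from compound 1, compound 2 and compound 3 cannot be read, so no new step comes from this result, and the series stays at one place: the limit of > 166000 nM in this assay, at which 4 of the 4 values shown sit.

The compounds shown leave open whether any group at this place gives a numerical value in this assay.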